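The source may report more compounds than this note shows. Statements on the series, on what has been measured and on what is new or still open speak of the compounds shown alone.

Working notes on the series. In a functional assay on LNCaP cells (Homo sapiens) for cytotoxicity, read by MTT assay (on this read-out higher numbers stand for weaker inhibition and lower numbers for stronger inhibition), compound 1 `COc1ccc2cc([C@H](C)c3nnc(SCc4c(C)cc(C)cc4C)n3-c3cccc(Cl)c3)ccc2c1` gives <= 400000 nM, which is a limit and not a number. Compound 2 `COc1ccc2cc([C@H](C)c3nnc(SCc4ccc(C)cc4)n3-c3ccc(F)cc3)ccc2c1` gives <= 400000 nM, which is also a limit. Among the compounds with values here, compound 3 `COc1ccc2cc([C@H](C)c3nnc(SCc4ccc(F)cc4)n3-c3ccc(F)cc3)ccc2c1` gives 104000 nM, the only true number so far. Compound 1 therefore has no exact place on the scale.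

Compound 4 `COc1ccc2cc([C@H](C)c3nnc(SCc4c(Cl)cccc4Cl)n3-c3cccc(Cl)c3)ccc2c1` differs from compound 1 as follows: 2,6-dichlorophenyl in place of 2,4,6-trimethylphenyl on a saturated chain carbon bound to a sulfur. The nearest measured change, also a swap of methyl for halogen on the benzyl group, is a step that the limit leaves unreadable from compound 2 to compound 3. It therefore supplies no size to carry over, only a direction that stays tentative. Within the data shown here, the sole number to lean on is that of compound 3 at 104000 nM, so a modest move towards stronger inhibition in this assay is expected. There is a real chance that compound 4 gives another limit. The estimated step is a step that the limit leaves unreadable from compound 1 to compound 4. For compound 4 the expected value is 150000 nM, with an estimated range of 50000 nM to 400000 nM.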

Compound 4, half-maximal inhibitory concentration: 73700 nM
Compound 4: the middle estimate sits 2.0-fold (0.31 log units) above what was measured; the range from low to high includes it.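

No size can be read for the change from compound 1 to compound 4 because compound 1 carries only a limit: the limit of <= 400000 nM in this assay, at which 2 of the 4 values shown sit.

The compounds shown leave open how large the change from 2,4,6-trimethylbenzyl to 2,6-dichlorobenzyl is on this read-out.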